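Toward a tetrazole analogue in the secretory phospholipase series

The compounds below may be only part of what the source reports. "The series", "measured", "known", "first", "only" and "open" are said of these compounds alone.

Compound 3 `CCCCCCCCCCCCCCCCCCOCC(CCCC)NC(C)=O` is one of three measured compounds sharing an octadecyloxy-bearing acetamide core. In an assay for inhibition of putative inactive group IIC secretory phospholipase A2 (Homo sapiens) (a lower number here means a stronger inhibitor, a higher number a weaker inhibitor), compound 3 gives 60000 nM. Compound 2 `CCCCCCCCCCCCCCCCCCOCC(CC[S+](C)[O-])NC(C)=O` gives 60000 nM in this assay, and no change at the digits printed from compound 2 to compound 3 (within the scatter). Compound 1 `C=CCCC(COCCCCCCCCCCCCCCCCCC)NC(C)=O` gives 8000 nM in this assay, the lowest of the three numbers; a 7.5-fold higher number from compound 1 to compound 3 (0.88 log units; beyond the scatter). Compound 3 therefore stands level with compound 2 and well above compound 1.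

Compound 4 `CCCCCCCCCCCCCCCCCCOCC(CCc1nnn[nH]1)NC(C)=O` is the next step from compound 3: 1H-tetrazol-5-yl in place of ethyl on a saturated chain carbon, three bonds along the chain from an amide-type nitrogen. For the measured compounds named here, two measured steps bear on this position. Exchanging ethyl for a sulfur-bearing group left the number unchanged, as no change at the digits printed from compound 2 to compound 3 (within the scatter) shows; exchanging it for vinyl shifted it, as a 7.5-fold higher number from compound 1 to compound 3 (0.88 log units; beyond the scatter) shows. Both changes at this carbon thus stayed within a modest range, and neither resembles a tetrazole closely. On that basis compound 4 is expected to sit near compound 3, with a 2.0-fold lower number from compound 3 to compound 4 (0.30 log units; within the scatter) as the estimated step and a small lean toward a lower number. Compound 4 is estimated at 30000 nM in this assay, within 8000 nM to 100000 nM.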

Compound 4, half-maximal inhibitory concentration: 570 nM
Estimate against measurement, compound 4: 53-fold (1.72 log units) above; measured number below the stated range.
By their numbers in this assay, from the lowest: compound 4; then compound 1; then compounds 2 and 3 (each within the scatter of the next).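

At this saturated chain carbon, three bonds along the chain from an amide-type nitrogen, the earlier groups had moved the number in this assay by no more than a 7.5-fold higher number from compound 1 to compound 3 (0.88 log units; beyond the scatter), whereas 1H-tetrazol-5-yl in place of ethyl gives a 110-fold lower number from compound 3 to compound 4 (2.02 log units; beyond the scatter). The step from the sulfur-bearing group is of the same printed size, a 110-fold lower number from compound 2 to compound 4 (2.02 log units; beyond the scatter), and even the best of the earlier compounds is passed, with a 14-fold lower number from compound 1 to compound 4 (1.15 log units; beyond the scatter), so this position can carry a far larger change in the number than ethyl, vinyl and the sulfur-bearing group had shown. No measurement here accounts for the size of this gain, so the change can be described but not explained.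

The compounds shown do not tell whether the gain belongs to the 1H-tetrazol-5-yl ring as such or would also appear with a carboxylic acid or a primary amide at this carbon. They also leave open how the number responds to a 1-methyl-1H-tetrazol-5-yl group, which lacks the ring's hydrogen-bond donor, or to a 1H-tetrazol-5-yl carried on a longer chain.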